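The source may hold more compounds than are shown below. What is called first, only, known or untested is meant among the compounds shown, and "the series" means these compounds.

Of the compounds shown here, three have numbers so far in an ADME assay on microsomes from liver (Mus musculus) for metabolic stability; a higher number here means that the compound lasts longer, a lower number that the compound disappears faster. Compound 1 `NS(=O)(=O)CC(=O)NCCSc1nonc1/C(=N/O)Nc1cccc(Cl)c1` gives 1.26 h, compound 2 `NS(=O)(=O)CC(=O)NCCSc1nonc1/C(=N/O)Nc1ccc(F)c(Br)c1` gives 1.12 h and compound 3 `NS(=O)(=O)CC(=O)NCCSc1nonc1/C(=N/O)Nc1cccc(Br)c1` gives 0.918 h in this series. Compound 2 lies within the scatter of both other compounds, so these numbers set no order among the three.

The step to follow leads to the unmeasured compound 4 `CS(=O)(=O)NCCSc1nonc1/C(=N/O)Nc1ccc(F)c(Br)c1`. Its difference from compound 2 is methylsulfonyl in place of (sulfamoylmethyl)carbonyl on an amine nitrogen, in short methylsulfonyl in place of (sulfamoylmethyl)carbonyl on an amine nitrogen.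

The measured steps change only the aromatic substitution: a 1.1-fold lower number from compound 1 to compound 2 (0.05 log units; within the scatter), a 1.4-fold lower number from compound 1 to compound 3 (0.14 log units; within the scatter) and a 1.2-fold lower number from compound 2 to compound 3 (0.09 log units; within the scatter). Each lies within the scatter, and all three keep the (sulfamoylmethyl)carbonyl group in place. They show that these aromatic changes moved this assay little, but they contain no measurement of the exchange at the amine nitrogen. Within the data shown here, the series therefore gives no direction for this step, and no shift beyond the scatter is expected, although the uncertainty is wide. The expectation starts from compound 2 at 1.12 h and stays close to it.

The estimated step is a 1.1-fold lower number from compound 2 to compound 4 (0.05 log units; within the scatter). For compound 4 the estimated half-life is 1 h, with an expected range from 0.4 h to 2.5 h.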

Compound 4, half-life: 0.29 h
The estimate for compound 4 lay 3.4-fold (0.54 log units) above the measured number; the whole stated range lies above it.
By their numbers in this assay, from the lowest: compound 4; then compounds 3, 2 and 1 (each within the scatter of the next).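

In this assay the amine nitrogen on the saturated chain carbon responds clearly to exchange of its substituent: methylsulfonyl in place of (sulfamoylmethyl)carbonyl gives a 3.9-fold lower number from compound 2 to compound 4 (0.59 log units; beyond the scatter) and stands as the only step shown that lies beyond the scatter. Among these compounds, the aromatic changes, including a 1.4-fold lower number from compound 1 to compound 3 (0.14 log units; within the scatter), stayed within the scatter with (sulfamoylmethyl)carbonyl in place, so this nitrogen is the first position where this assay shows a readable change. The step alters several things at once, from 7 heavy atoms and 1 hydrogen-bond donor in the leaving group to 4 heavy atoms and 0 hydrogen-bond donors in the entering group, and no measurement at hand accounts for the shorter half-life.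

From the compounds shown here alone, it remains open whether the shorter half-life goes with the sulfonyl attachment on the nitrogen or with the absence of the sulfamoyl end, a question that a plain acetyl or an ethylsulfonyl group on the same nitrogen would address. Also open, going by these compounds, is whether the aromatic substitution would stay as quiet with methylsulfonyl on the nitrogen, since only compound 4 carries that group here.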